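Lengthening the tertiary alcohol side chain on a naphthoquinone ester

A few compounds are considered here, and "the series" means these few. Any claim that something is new, unique, unknown or untested is made for them only; others in the source may bear on it.

Measured so far:
Compound 1 `CC(=O)OCCC(=O)O[C@H](CC=C(C)C)C1=CC(=O)c2c(O)ccc(O)c2C1=O`: 15700 nM
Compound 2 `CCCCCCC(C)(O)CC(=O)O[C@H](CC=C(C)C)C1=CC(=O)c2c(O)ccc(O)c2C1=O`: > 100000 nM
Compound 3 `CC[C@@](C)(O)CC(=O)O[C@H](CC=C(C)C)C1=CC(=O)c2c(O)ccc(O)c2C1=O`: 12700 nM

All three share one core, an ester of a naphthoquinone, and differ only in the acid part. In a functional assay on DU-145 cells (Homo sapiens) for cytotoxicity, read by MTT assay (on this read-out higher numbers stand for weaker inhibition and lower numbers for stronger inhibition), compound 3 gives 12700 nM, the lowest of the two numbers reported, and compound 1 sits within the scatter of it, as a 1.2-fold lower number from compound 1 to compound 3 (0.09 log units; within the scatter) shows. For compound 2 the assay reports only a limit, (the limit of > 100000 nM in this assay, at which 1 of the 3 values shown sits), not a number.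

Compound 4 `CCC(O)(CC)CC(=O)O[C@H](CC=C(C)C)C1=CC(=O)c2c(O)ccc(O)c2C1=O` is the next step: 1-ethyl-1-hydroxypropyl in place of 1-hydroxy-1-methylpropyl on a saturated chain carbon bound to a carbonyl carbon. The acid part keeps its hydroxyl and grows by a single carbon.

Two measured steps speak to this. The long chain of compound 2 against the short one of compound 3 gave an at least 7.8-fold lower number from compound 2 to compound 3 (0.89 log units; beyond the scatter), so a much larger chain weakened the inhibition markedly. A change of similar size but different kind, a 1.2-fold lower number from compound 1 to compound 3 (0.09 log units; within the scatter), stayed within the scatter. One added carbon is far short of the four that separate compound 2 from compound 3, so compound 4 is expected to show at most a slight rise, a 1.3-fold higher number from compound 3 to compound 4 (0.13 log units; within the scatter), likely within the scatter.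

Compound 4 is therefore estimated at 17000 nM, between 8000 nM and 40000 nM.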

Compound 4, half-maximal inhibitory concentration: 67000 nM
The estimate for compound 4 lay 3.9-fold (0.60 log units) below the measured number; the whole stated range lies below it.
By their numbers in this assay, from the lowest: compounds 3 and 1 (each within the scatter of the next); then compound 4. At a limit, above all of these: compound 2.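

A small change at this position, on a saturated chain carbon bound to a carbonyl carbon, turns out to matter: with the hydroxyl kept, 1-ethyl-1-hydroxypropyl in place of 1-hydroxy-1-methylpropyl gave a 5.3-fold higher number from compound 3 to compound 4 (0.72 log units; beyond the scatter). The earlier compounds shown here showed a large loss only with the much longer 1-hydroxy-1-methylheptyl, so in this assay this acid part tolerates less growth than they suggested, and the acetoxymethyl ester also keeps its lead, with a 4.3-fold higher number from compound 1 to compound 4 (0.63 log units; beyond the scatter). Against the long chain the comparison reads an at least 1.4-fold lower number from compound 2 to compound 4 (0.17 log units; that floor lies within the scatter), so that floor does not separate the two, and the value for compound 2 is only a limit: the limit of > 100000 nM in this assay, at which 1 of the 4 values shown sits.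

The step also removes the one defined stereocentre of the 1-hydroxy-1-methylpropyl group, so the added carbon and the lost stereocentre cannot be told apart here, and the other mirror-image form of compound 3 would bear on that question. On these data alone, it also remains open whether the hydroxyl itself is needed, which an amine or a carboxylic acid in its place, or a chain with no hydroxyl at all, would begin to answer.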